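A few compounds are considered here, and "the series" means these few. Any claim that something is new, unique, unknown or untested is made for them only; others in the source may bear on it.

Compound 1 `NC(=O)Cn1c(=O)n(C2OC(CO)[C@@H](O)[C@H]2O)c2nc(N)nc(O)c21`: 72%
Compound 2 `COc1ccc(Cn2c(=O)n(C3OC(CO)[C@@H](O)[C@H]3O)c3nc(N)nc(O)c32)cc1`: 14%
Compound 3 `Nc1nc(O)c2c(n1)n(C1OC(CO)[C@@H](O)[C@H]1O)c(=O)n2Cc1ccc([N+](=O)[O-])cc1`: 16%

In a functional assay on the whole organism with Mus musculus as the target (on this read-out lower numbers stand for smaller maximal responses and higher numbers for larger maximal responses), compound 3 stands second highest of the three numbers, close to compound 2 and far below compound 1. Compound 4 `CN(C)CCCn1c(=O)n(C2OC(CO)[C@@H](O)[C@H]2O)c2nc(N)nc(O)c21` differs from compound 3 by 2-(dimethylamino)ethyl in place of 4-nitrophenyl on a saturated chain carbon bound to an aromatic nitrogen. Within the data shown here, the steps that bear on this are a number 56 percentage points lower from compound 1 to compound 3 (beyond the scatter) and a number 58 percentage points lower from compound 1 to compound 2 (beyond the scatter), both large and both at the same saturated chain carbon bound to an aromatic nitrogen, whereas a number 2 percentage points higher from compound 2 to compound 3 (within the scatter). Among the measured compounds shown here, compound 4 gives up the aromatic ring that those two steps introduced, yet its 3-(dimethylamino)propyl chain has no measured counterpart, so the size of the step is uncertain. Compound 4 is therefore expected to move upward in this assay by a number 29 percentage points higher from compound 3 to compound 4 (beyond the scatter), to an estimated 45% within a range of 15% to 80%.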

Compound 4, largest response reached (reported as maximal response), in percent of the reference or control that the assay uses: 63%
Beside the measured number, compound 4's estimate is 18 percentage points below it; the range from low to high includes it.
By their numbers in this assay, from the lowest: compounds 2 and 3 (each within the scatter of the next); then compounds 4 and 1 (each within the scatter of the next).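

At this saturated chain carbon bound to an aromatic nitrogen, 2-(dimethylamino)ethyl in place of an aryl group gives a number 47 percentage points higher from compound 3 to compound 4 (beyond the scatter) and a number 49 percentage points higher from compound 2 to compound 4 (beyond the scatter) in this assay. Against carbamoyl, the same group gives a number 9 percentage points lower from compound 1 to compound 4 (within the scatter), so a high number here does not depend on the carbamoyl group, and among these four compounds the two with an aromatic ring in this chain give the lowest numbers. Nothing available explains this difference.

From the compounds shown here alone, it remains open whether the dimethylamino group matters or only the absence of the ring, which a plain alkyl chain or a chain ending in a carboxylic acid would address. Going by these compounds, the effect of a shorter or longer chain carrying the same amine also remains open.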